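Swapping Dimethoxyphenyl for Chlorophenyl: Cytotoxicity Outlook

This account rests on a few compounds, and the source may have more. Where it says the series, first, only, none or still open, it means among the compounds named here.

Measured compounds:
compound 1 `COc1ccc(-c2nc(SCC(=O)c3sc(-c4ccccc4)nc3C)nc(N)c2C#N)cc1` — "not determined" (no result reported)
compound 2 `COc1ccc(-c2nc(SCC(=O)c3sc(-c4ccccc4)nc3C)[nH]c(=O)c2C#N)cc1OC` — 91800 nM
compound 3 `COc1ccc(-c2nc(SCC(=O)c3sc(-c4ccc(Cl)cc4)nc3C)[nH]c(=O)c2C#N)cc1OC` — "not determined" (no result reported)

In an ADME assay on HEK293 cells (Homo sapiens) for cytotoxicity, read by MTT assay, with a stated time of 48 h (a lower number here means a stronger inhibitor, a higher number a weaker inhibitor), compound 2 gives 91800 nM, a weak effect on cell survival. Compound 1 has no result in this assay, its entry reading "not determined" (no result reported). Among the measured compounds shown here, compound 3 stands without a single number in this assay, its entry reading "not determined" (no result reported), and a further entry also lacks one, so the only anchor is compound 2.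

Compound 4 `Cc1nc(-c2ccc(Cl)cc2)sc1C(=O)CSc1nc(-c2ccc(Cl)cc2)c(C#N)c(=O)[nH]1` differs from compound 3 by 4-chlorophenyl in place of 3,4-dimethoxyphenyl on an aromatic carbon. For the measured compounds named here, no step between two measured compounds exists in this set, so the size of this change cannot be read from data. Given that compound 2 shows weak cytotoxicity at 91800 nM, and that compound 3 and compound 4 share most of its framework, no step beyond the usual scatter is expected; compound 4 is expected to stay in the same weak range. Compound 4 is estimated at 90000 nM, within 30000 nM to 300000 nM.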

Compound 4, half-maximal inhibitory concentration: 75100 nM
Beside the measured number, compound 4's estimate is 1.2-fold (0.08 log units) above it, within the range that was stated.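

Among the compounds shown here, compound 4 yields no new step, since its neighbour differing in one place, compound 3, has no single number to compare with. From the compounds shown here alone, what replacing 3,4-dimethoxyphenyl with 4-chlorophenyl does on its own in this assay stays open. No supporting data bear on this result.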